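The source may report more compounds than this note shows. Statements on the series, on what has been measured and on what is new or still open speak of the compounds shown alone.

Measured in a functional assay on MCF7 cells (Homo sapiens) for cytotoxicity, read by MTT assay; a lower number here means a stronger inhibitor, a higher number a weaker inhibitor:
Compound 1 `CCCCCCCCC1CC1CCCCCCCC(=O)OC[C@H](CO[C@@H]1O[C@H](CO)[C@@H](O)[C@H](O)[C@H]1O)OC(=O)CCCCCCCC1CC1CCCCCCCC`: 99800 nM
Compound 2 `C=CCCCCCCCCC(=O)OC[C@H](CO[C@@H]1O[C@H](CO)[C@@H](O)[C@H](O)[C@H]1O)OC(=O)CCCCCCCCC=C`: 32500 nM
Compound 3 `CCCCCCCCCCCC(=O)OC[C@H](CO[C@@H]1O[C@H](CO)[C@@H](O)[C@H](O)[C@H]1O)OC(=O)CCCCCCCCCCC`: 32600 nM

Compound 1 has the highest number of the three, so it is the weakest inhibitor here. Its gaps to compound 2 and compound 3 both lie beyond the scatter, while those two lie within the scatter of each other.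

Compound 4 `CCCCCCCC/C=C\CCCCCCCC(=O)O[C@H](COC(=O)CCCCCCCC1CC1CCCCCCCC)CO[C@@H]1O[C@H](CO)[C@@H](O)[C@H](O)[C@H]1O` has not yet been measured. It differs from compound 1 in one place: dec-1-en-1-yl in place of 2-octylcyclopropyl on a saturated chain carbon, seven bonds along the chain from a carbonyl carbon. In words, dec-1-en-1-yl stands in place of 2-octylcyclopropyl on a saturated chain carbon, seven bonds along the chain from a carbonyl carbon. Among the measured compounds shown here, no measured pair isolates a change like this, so any expectation is loose. Only compound 1 (99800 nM) carries 2-octylcyclopropyl on both chains, and compound 3 (32600 nM) carries none. Compound 4 keeps one such group, so a modest move toward a lower number is expected. The expected step of a 1.7-fold lower number from compound 1 to compound 4 (0.22 log units; within the scatter) is small and probably within the scatter. For compound 4 the estimate is 60000 nM, with an expected range of 28000 nM to 130000 nM.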

Compound 4, half-maximal inhibitory concentration: 38200 nM
The estimate for compound 4 lay 1.6-fold (0.20 log units) above the measured number, within the range that was stated.
By their numbers in this assay, from the lowest: compounds 2, 3 and 4 (each within the scatter of the next); then compound 1.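

In this assay, putting dec-1-en-1-yl in place of 2-octylcyclopropyl on a saturated chain carbon, seven bonds along the chain from a carbonyl carbon, gives a 2.6-fold lower number from compound 1 to compound 4 (0.42 log units; beyond the scatter). This single change moves the number beyond the usual scatter, even though compound 4 keeps 2-octylcyclopropyl on its other chain, so this position responds to a change on one chain alone. The change removes a three-membered ring and adds a double bond, and nothing available explains why the number moves.

Compound 4 does not separate the loss of the ring from the gain of the double bond, so either could account for the step. Also open, from the compounds shown here alone, is how a fully saturated chain, a longer chain or a hydroxyl group at this place would compare with compound 1.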